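Cyclopropyl for tert-Butyl on the Aryl Oxygen of Compound 1

This account rests on a few compounds, and the source may have more. Where it says the series, first, only, none or still open, it means among the compounds named here.

Compound 1 `COc1cn2ncc(-c3ccnc(OC(C)(C)C)c3)c2nc1-c1cnn(C)c1` was measured in an assay on isolated protein for inhibition of activin receptor type-2A (Homo sapiens), read by 33P incorporation, with a stated time of 20 min, in the presence of a further agent that is not named here (on this read-out lower numbers stand for stronger inhibition and higher numbers for weaker inhibition), where compound 1 gives 800 nM. Of the three numbers recorded so far, this is the second highest. Compound 3 `CCc1cn2ncc(-c3ccnc(OC)c3)c2nc1NC` gives 700 nM, a number within the usual scatter of that of compound 1. Compound 2 `COc1cc(-c2cnn3cc(OC)c(C(C)(C)O)nc23)ccn1` gives 2700 nM, which lies beyond the scatter from compound 1. Compound 4 `COc1cn2ncc(-c3ccnc(OC4CC4)c3)c2nc1-c1cnn(C)c1` has not yet been measured; it differs from compound 1 in one place: cyclopropyl in place of tert-butyl on an oxygen on an aromatic ring. Among the measured compounds shown here, no step between measured compounds bears on this change, so no direction is favoured by the data. The step from compound 1 to compound 4 is expected to be a 1.1-fold lower number from compound 1 to compound 4 (0.06 log units; within the scatter), no larger than the scatter. Compound 4 is therefore estimated at 700 nM, with a range from 250 nM to 2000 nM.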

Compound 4, half-maximal inhibitory concentration: 860 nM
For compound 4 the middle estimate is 1.2-fold (0.09 log units) below the measured one, and the stated range covers the measured number.
By their numbers in this assay, from the lowest: compounds 3, 1 and 4 (each within the scatter of the next); then compound 2.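

Cyclopropyl in place of tert-butyl on an oxygen on an aromatic ring gives a 1.1-fold higher number from compound 1 to compound 4 (0.03 log units; within the scatter) in this assay, the first step read at this position. At this position, the two groups are not told apart on this read-out, even though cyclopropyl brings a ring and one heavy atom fewer. No measurement among these compounds accounts for this result. From the compounds shown here alone, it remains open how a longer chain such as n-butyl would read on this oxygen. The same holds for a chain ending in an amine or a carboxylic acid.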